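The source may hold more compounds than are shown below. What is called first, only, known or untested is meant among the compounds shown, and "the series" means these compounds.

Measured compounds in a functional assay on MNK45 cells (Homo sapiens) for inhibition, read by MTT assay, with a stated time of 48 h; on this read-out higher numbers stand for weaker inhibition and lower numbers for stronger inhibition:
- compound 1, `Cc1ccc(NC(=S)NC(=O)c2ccc(OCc3ccccc3)cc2)cc1-c1nc2ccccc2[nH]1`: 57800 nM
- compound 2, `Cc1ccc(NC(=S)NC(=O)c2ccc(OCc3cccc(C(F)(F)F)c3)cc2)cc1-c1nc2ccccc2[nH]1`: 6050 nM
- compound 3, `Cc1ccc(NC(=O)NC(=O)c2ccc(OCc3ccccc3F)cc2)cc1-c1nc2ccccc2[nH]1`: 1830 nM

Compound 3 gives the lowest number of the three in this assay; compound 2 lies a 9.6-fold lower number from compound 1 to compound 2 (0.98 log units; beyond the scatter) away from compound 1, and compound 3 sits further down still, beyond the scatter from both. Compound 4, `Cc1ccc(NC(=O)NC(=O)c2ccc(OCc3ccc(F)cc3)cc2)cc1-c1nc2ccccc2[nH]1`, keeps the urea-linked core of compound 3 and changes only the fluorine position on the benzyl ring: 4-fluorophenyl in place of 2-fluorophenyl on a saturated chain carbon bound to an oxygen on an aromatic ring.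

The one step that is shown, a 9.6-fold lower number from compound 1 to compound 2 (0.98 log units; beyond the scatter), concerns a trifluoromethyl entering in place of hydrogen on the benzyl ring of the thiourea pair, which shows that the substituent on this ring can move the number well beyond the scatter. Among the measured compounds shown here, no measured pair moves a fluorine from one ring position to another, so nothing here speaks to the direction of the change from compound 3 to compound 4. With the same atoms joined differently, the expected step is a 1.0-fold lower number from compound 3 to compound 4 (0.01 log units; within the scatter), that is, none beyond the scatter. Compound 4 is therefore estimated at 1800 nM in this assay, with a range from 600 nM to 5500 nM.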

Compound 4, half-maximal inhibitory concentration: 240 nM
Compound 4: middle estimate off by 7.5-fold (0.88 log units), on the high side; measured number outside the range, below it.
By their numbers in this assay, from the lowest: compound 4; then compound 3; then compound 2; then compound 1.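

In this assay, the position of the fluorine on the benzyl ring counts by itself: with the same atoms joined differently, 4-fluorophenyl in place of 2-fluorophenyl on a saturated chain carbon bound to an oxygen on an aromatic ring gives a 7.6-fold lower number from compound 3 to compound 4 (0.88 log units; beyond the scatter). The earlier step, a 9.6-fold lower number from compound 1 to compound 2 (0.98 log units; beyond the scatter), had shown only that this ring responds when a trifluoromethyl enters in place of hydrogen, so a change of substituent was involved there, whereas here the substituent stays and only its place on the ring differs. Nothing measured here bears on why moving the fluorine has this effect.

The compounds shown leave open whether the same move of the fluorine would shift the number in the same direction in the thiourea series, since the two fluorinated compounds here are both urea-linked and the thiourea pair carries no fluorobenzyl group. They also leave open whether a chlorine, a methoxy group or an amine in place of the fluorine of compound 4 would keep, raise or lower the number.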